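A few compounds are considered here, and "the series" means these few. Any claim that something is new, unique, unknown or untested is made for them only; others in the source may bear on it.

Measured compounds:
- compound 1 `Cc1cccnc1-c1ccc(C(=O)Nc2ccc(Cl)cc2)cc1`: in a functional assay for antagonist activity at transient receptor potential cation channel subfamily V member 1 (Homo sapiens), read by FLIPR (on this read-out lower numbers stand for stronger inhibition and higher numbers for weaker inhibition), compound 1 gives 1500 nM
- compound 2 `Cc1cccnc1-c1ccc(C(=O)Nc2ccc(C(F)(F)F)cc2)cc1`: in this assay compound 2 gives 65 nM
- compound 3 `CCCOc1cccnc1-c1ccc(C(=O)Nc2ccc(C(C)(C)C)cc2)cc1`: in this assay compound 3 gives 62 nM

Compound 3 holds the lowest number of the three, but its gap to compound 2 lies within the scatter, so the two stand together at the low end, with compound 1 well apart from both. Within the data shown here, the single measured step, a 23-fold lower number from compound 1 to compound 2 (1.36 log units; beyond the scatter), concerns the group on the ring that carries the amide nitrogen, not the ring changed here.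

Compound 4 `CC(C)(C)c1ccc(NC(=O)c2ccc(-c3ncccc3NS(C)(=O)=O)cc2)cc1` differs from compound 3 by methanesulfonamido in place of propoxy on an aromatic carbon. Among the measured compounds shown here, no measured pair alters that substituent alone; compound 2 and compound 3 differ there and at the amide end at once, and their two values lie within the scatter of each other, so nothing can be read from them for the propoxy by itself. For the measured compounds named here, the step from compound 3 to compound 4 therefore has no precedent in this set, and no direction beyond the scatter can be argued from the data.

Compound 4 is accordingly expected to sit near compound 3, the step being a 1.8-fold higher number from compound 3 to compound 4 (0.25 log units; within the scatter), with an estimate of 110 nM in this assay and a range from 25 nM to 600 nM to cover the absence of a guiding step.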

Compound 4, half-maximal inhibitory concentration: 152 nM
Beside the measured number, compound 4's estimate is 1.4-fold (0.14 log units) below it; the range from low to high includes it.
By their numbers in this assay, from the lowest: compounds 3 and 2 (each within the scatter of the next); then compound 4; then compound 1.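

Methanesulfonamido in place of propoxy, on an aromatic carbon of the six-membered ring with 1 nitrogen, ortho to a large group and two atoms from the ring nitrogen, gives the first readable step at this position in this assay: a 2.5-fold higher number from compound 3 to compound 4 (0.39 log units; beyond the scatter). The step lies beyond the scatter but is modest, so this position tolerates an exchange of propoxy, with 0 hydrogen-bond donors, for methanesulfonamido, with 1 hydrogen-bond donor, and compound 4 still reads 152 nM in this assay. Nothing on hand gives a reason for the size or direction of this step.

The compounds shown leave open how an amine, a carboxylic acid or a longer alkoxy chain would read at this position, and whether a plain hydrogen there would give a higher or lower number than propoxy. Also open, going by these compounds, is whether the step from propoxy to methanesulfonamido keeps its size with trifluoromethyl or chloro at the amide end, since it rests on a single pair of compounds.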